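Cyclohexylmethoxy to 2-Fluorobenzyloxy on a Translocator Protein Ligand

A few compounds are considered here, and "the series" means these few. Any claim that something is new, unique, unknown or untested is made for them only; others in the source may bear on it.

Compound 2 `CCN(CC)C(=O)Cc1c(-c2ccc(OCC3CCCCC3)cc2)nn2c(C)cc(C)nc12` gives 3.6 nM in an assay on isolated protein (kidney, strain Wistar) for displacement of a labelled ligand from Translocator protein (Rattus norvegicus), read by scintillation counting, with a stated time of 90 min; a higher number here means a weaker inhibitor, a lower number a stronger inhibitor. Going by the values given here, it stands beside the only other measured compound, compound 1 `CCN(CC)C(=O)Cc1c(-c2ccc(OCC3CC3)cc2)nn2c(C)cc(C)nc12`, which gives 3 nM in this assay, and the step of a 1.2-fold higher number from compound 1 to compound 2 (0.08 log units; within the scatter) separates them by no more than the usual scatter. The change now considered produces compound 3 `CCN(CC)C(=O)Cc1c(-c2ccc(OCc3ccccc3F)cc2)nn2c(C)cc(C)nc12`: 2-fluorophenyl in place of cyclohexyl on a saturated chain carbon bound to an oxygen on an aromatic ring. Among the compounds with values here, only one measured step touches this position, namely a 1.2-fold higher number from compound 1 to compound 2 (0.08 log units; within the scatter), and it showed that swapping one saturated ring for another at the chain carbon bound to the aryl oxygen left the inhibition constant essentially unchanged. Within the data shown here, no measured compound carries an aromatic ring at this position, so the data give no direct guide for that part of the change. Compound 3 is therefore expected to stay close, with the step of a 1.1-fold higher number from compound 2 to compound 3 (0.05 log units; within the scatter) expected to fall within the scatter. Compound 3 is estimated at 4 nM, within a range from 1.5 nM to 12 nM.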

Compound 3, inhibition constant: 0.31 nM
Beside the measured number, compound 3's estimate is 13-fold (1.11 log units) above it; the measured number lies below the stated range.
By their numbers in this assay, from the lowest: compound 3; then compounds 1 and 2 (each within the scatter of the next).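

The position is not indifferent to the group it carries: in this assay, 2-fluorophenyl in place of cyclohexyl gives a 12-fold lower number from compound 2 to compound 3 (1.06 log units; beyond the scatter), and 2-fluorophenyl in place of cyclopropyl gives a 9.7-fold lower number from compound 1 to compound 3 (0.99 log units; beyond the scatter). The two saturated rings had stayed within the scatter of each other, so their agreement did not extend to this aromatic ring, and compound 3 is the strongest inhibitor of the three. The data shown offer no measurement that accounts for this gain.

Going by these compounds alone, compound 3 is the only compound with an aromatic ring on this chain carbon, so the part played by the ring cannot be separated from that played by the fluorine. Plain phenyl would settle that question, while a longer chain carrying the ring, or an amine on the ring, remains untested in what is shown here.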